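Replacing a cyclopropyl with a piperidinylethyl urea on a benzothiazole

A few compounds are considered here, and "the series" means these few. Any claim that something is new, unique, unknown or untested is made for them only; others in the source may bear on it.

Compound 1 `COc1ncc(-c2ccc3nc(NC4CC4)sc3c2)cc1NS(=O)(=O)c1ccc(F)cc1` is the weaker of the two measured compounds: in a functional assay on U-87MG ATCC cells for antiproliferative activity against U-87 MG (Homo sapiens), read by MTT assay, with a stated time of 72 h (a higher number here means a weaker inhibitor, a lower number a stronger inhibitor), compound 1 gives 1500 nM, while compound 2 `CCN(CC)CCNC(=O)Nc1nc2ccc(-c3cnc(OC)c(NS(=O)(=O)c4ccc(C)cc4)c3)cc2s1` gives 360 nM, a gap beyond the scatter. Compound 3 `COc1ncc(-c2ccc3nc(NC(=O)NCCN4CCCCC4)sc3c2)cc1NS(=O)(=O)c1ccc(F)cc1` differs from compound 1 in one place, ((2-(piperidin-1-yl)ethyl)carbamoyl in place of cyclopropyl on a nitrogen on an aromatic ring). For the measured compounds named here, no measured pair shows this exact change, so the step is expected to be a gain of moderate size, roughly toward where compound 2 sits, as a 3.8-fold lower number from compound 1 to compound 3 (0.57 log units; beyond the scatter). Compound 3 is therefore estimated at 400 nM, within a range from 150 nM to 1200 nM.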

Compound 3, half-maximal inhibitory concentration: 750 nM
Compound 3: middle estimate off by 1.9-fold (0.27 log units), on the low side; low and high end bracket the measured number.
By their numbers in this assay, from the lowest: compound 2; then compounds 3 and 1 (each within the scatter of the next).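

In this assay, the cyclopropyl on this nitrogen on an aromatic ring gives way to (2-(piperidin-1-yl)ethyl)carbamoyl, with 11 heavy atoms instead of 3, and the result is a 2.0-fold lower number from compound 1 to compound 3 (0.30 log units; within the scatter). This position therefore accepts a much larger group, but that group brings no gain that can be told from the scatter. Nothing measured here explains this result. Compound 2 differs from compound 3 in more than one place, so its value cannot be tied to any single part. As far as these compounds go, it remains open whether a morpholine in place of the piperidine, or a longer chain before it, would change the number.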